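The compounds below may be only part of what the source reports. "The series", "measured", "known", "first", "only" and "open" are said of these compounds alone.

Measured so far in an ADME assay on THP-1 cells (Homo sapiens) for cytotoxicity, with a stated time of 24 h; a higher number here means a weaker inhibitor, a lower number a stronger inhibitor:
Compound 1 `N#C[Se]c1ccc(NC(=O)c2ccccc2C(=O)O)cc1`: > 25000 nM (a limit)
Compound 2 `O=C(NC(=[Se])Nc1ccc([Se][Se]c2ccc(NC(=[Se])NC(=O)c3ccccc3)cc2)cc1)c1ccccc1`: > 25000 nM (a limit)

Compound 1 stands at the edge of what this assay can report: compound 1 gives > 25000 nM, a limit and not a number. Compound 2 gives > 25000 nM, which is likewise a limit. Within the data shown here, both measured compounds thus sit at the limit of > 25000 nM in this assay, at which 2 of the 2 values shown sit, and no step between measured compounds is available as a guide.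

Compound 3 `N#C[Se]c1ccc(NC(=O)c2ccccc2-c2ccccc2C(=O)O)cc1` has not yet been measured. It carries 2-carboxyphenyl in place of carboxy on an aromatic carbon, ortho to a large group (2-carboxyphenyl in place of carboxy on an aromatic carbon). Compound 1 offers only the limit > 25000 nM as a starting point, so no step beyond the scatter is expected in either direction. The expected change, a step that the limit leaves unreadable from compound 1 to compound 3, is an estimate only. In this assay the estimate for compound 3 is 28000 nM, with an expected range from 10000 nM to 60000 nM.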

Compound 3, half-maximal inhibitory concentration: > 25000 nM
Compound 3 was reported as a limit; the forecaster's own chance of this, stated with the estimate: 70%; the middle value lies beyond the limit too.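

In this assay compound 3 gives > 25000 nM, a limit and not a number, so no step from compound 1 to compound 3 can be read: the limit of > 25000 nM in this assay, at which 3 of the 3 values shown sit.

The compounds shown leave open which change in structure, if any, would give a measurable value in this assay.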